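A few compounds are considered here, and "the series" means these few. Any claim that something is new, unique, unknown or untested is made for them only; others in the source may bear on it.

In a functional assay on K562 cells (Homo sapiens) for antiproliferative activity, read by MTT assay, with a stated time of 72 h (a lower number here means a stronger inhibitor, a higher number a weaker inhibitor), compound 1 (`COc1cc(C(=O)c2sc3ccccc3c2-c2ccccc2)cc(OC)c1OC`) gives 2100 nM as its value, compound 2 (`COc1cc(C(=O)c2sc3ccccc3c2-c2ccc(C)cc2)cc(OC)c1OC`) gives 3500 nM and compound 3 (`COc1ccccc1-c1c(C(=O)c2cc(OC)c(OC)c(OC)c2)sc2ccccc12`) gives 3400 nM on the same scale. Compound 3 therefore stands level with both others (a 1.6-fold higher number from compound 1 to compound 3 (0.21 log units; within the scatter)) and (a 1.0-fold lower number from compound 2 to compound 3 (0.01 log units; within the scatter)). Compound 4 (`COc1cc(C(=O)c2sc3ccccc3c2Nc2ccc(Cl)cc2)cc(OC)c1OC`) has (4-chlorophenyl)amino in place of 2-methoxyphenyl on an aromatic carbon. Going by the values given here, no measured compound carries this group, so the evidence is indirect. The closest guides are two small steps (a 1.7-fold higher number from compound 1 to compound 2 (0.22 log units; within the scatter)) and (a 1.0-fold lower number from compound 2 to compound 3 (0.01 log units; within the scatter)), and no step beyond the scatter is expected in this assay here, though with wide uncertainty. The expected change is small (a 1.1-fold lower number from compound 3 to compound 4 (0.05 log units; within the scatter)). The estimated value of compound 4 is (3000 nM), within an expected range (800 nM to 10000 nM).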

Compound 4, half-maximal inhibitory concentration: 1100 nM
For compound 4 the middle estimate is 2.7-fold (0.44 log units) above the measured one, within the range that was stated.
By their numbers in this assay, from the lowest: compounds 4, 1, 3 and 2 (each within the scatter of the next, the first and the last beyond it).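

In this assay, going by these compounds alone, (4-chlorophenyl)amino at this position gives the first steps beyond the scatter, against 2-methoxyphenyl (a 3.1-fold lower number from compound 3 to compound 4 (0.49 log units; beyond the scatter)) and against 4-methylphenyl (a 3.2-fold lower number from compound 2 to compound 4 (0.50 log units; beyond the scatter)). Against the unsubstituted phenyl the step stays within the scatter (a 1.9-fold lower number from compound 1 to compound 4 (0.28 log units; within the scatter)), so the change separates compound 4 only from the two substituted aryl compounds. Nothing available accounts for this result. The compounds shown leave open whether the step follows the amino link or the chlorine, and how a plain phenylamino or a 4-chlorophenyl group would read here.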